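The source may report more compounds than this note shows. Statements on the series, on what has been measured and on what is new or still open speak of the compounds shown alone.

Measured so far in a functional assay on NCI-H460 cells (Homo sapiens) for cytotoxicity, read by MTT assay, with a stated time of 3 days; on this read-out higher numbers stand for weaker inhibition and lower numbers for stronger inhibition
- compound 1 `CCNc1nc(SCc2nc3ccccc3[nH]2)nc(-c2ccccc2)c1C#N` gives 2.87 nM
- compound 2 `N#Cc1c(Nc2ccccn2)nc(SCc2nc3ccccc3[nH]2)nc1-c1ccccc1` gives 2.8 nM
- compound 3 `N#Cc1c(NNC(N)=S)nc(SCc2nc3ccccc3[nH]2)nc1-c1ccccc1` gives 3.37 nM

Compound 3 stands level with compound 1 and compound 2. All three measured steps change only the group on a nitrogen on an aromatic ring, and each stays within the scatter: pyridin-2-yl for ethyl (a 1.0-fold lower number from compound 1 to compound 2 (0.01 log units; within the scatter)), then the group of 4 heavy atoms for ethyl (a 1.2-fold higher number from compound 1 to compound 3 (0.07 log units; within the scatter)) and for pyridin-2-yl (a 1.2-fold higher number from compound 2 to compound 3 (0.08 log units; within the scatter)). Compound 4 `N#Cc1c(NC(N)=S)nc(SCc2nc3ccccc3[nH]2)nc1-c1ccccc1` changes that same group once more (a group of 3 heavy atoms (1 carbon, 1 nitrogen, 1 sulfur; no ring) in place of a group of 4 heavy atoms (1 carbon, 2 nitrogen, 1 sulfur; no ring), on a nitrogen on an aromatic ring). Given those three steps, no change beyond the scatter is expected in this assay here. The expected step is small (a 1.1-fold lower number from compound 3 to compound 4 (0.05 log units; within the scatter)). Compound 4 is estimated at 3 nM (1.4 nM to 6.5 nM).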

Compound 4, half-maximal inhibitory concentration: 3.37 nM
Compound 4: the middle estimate sits 1.1-fold (0.05 log units) below what was measured; low and high end bracket the measured number.
By their numbers in this assay, from the lowest: compounds 2, 1, 3 and 4 (each within the scatter of the next).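

In this assay, the group of 3 heavy atoms on this nitrogen gives no change at the digits printed from compound 3 to compound 4 (within the scatter), and comparison with the other two compounds gives a 1.2-fold higher number from compound 2 to compound 4 (0.08 log units; within the scatter) and a 1.2-fold higher number from compound 1 to compound 4 (0.07 log units; within the scatter). All four groups tried here therefore read alike, and the result adds that going from 2 hydrogen-bond donors to 1 in this group does not shift the number beyond the scatter. No measured evidence explains this flat result.

On these data alone, whether a carboxylic acid or a longer chain such as octyl on this nitrogen would also read alike remains open. The compounds shown also all share one core, so they say nothing about changes elsewhere in the molecule.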